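Working notes: same side-chain change on a second core

The compounds below may be only part of what the source reports. "The series", "measured", "known", "first", "only" and "open" are said of these compounds alone.

Measured so far:
compound 1, `O=C(O)/C=N/OC(c1ccc(OCc2ccc3ccccc3n2)cc1)C1CCCCCC1`, in a functional assay for inhibition of Polyunsaturated fatty acid 5-lipoxygenase (Homo sapiens) (a lower number here means a stronger inhibitor, a higher number a weaker inhibitor), gives 18 nM
compound 2, `C/C(=N\OC(c1ccc(OCc2ccc3ccccc3n2)cc1)C1CCCCCC1)C(=O)O`, in this assay gives 13 nM
compound 3, `O=C(O)/C=N/OC(c1ccc(OCc2nc3ccccc3s2)cc1)C1CCCCC1`, in this assay gives 60 nM

Compound 1 and compound 2 share one core and differ only in the side chain on the oxygen: a group of 6 heavy atoms (3 carbon, 1 nitrogen, 2 oxygen; no ring) in place of a group of 5 heavy atoms (2 carbon, 1 nitrogen, 2 oxygen; no ring), on an oxygen on a saturated carbon. The step is a 1.4-fold lower number from compound 1 to compound 2 (0.14 log units; within the scatter), so the two numbers cannot be told apart here.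

Compound 3 carries the smaller of the two side chains on a different core; the difference between the two cores is not broken down here. Compound 3 gives the highest number of the three, and its gap to compound 1 and to compound 2 lies beyond the scatter in each case, so on the shared side chain the core of compound 3 reads as the weaker of the two.

Compound 4, `C/C(=N\OC(c1ccc(OCc2nc3ccccc3s2)cc1)C1CCCCC1)C(=O)O`, is not yet measured. It puts the larger side chain onto the core of compound 3: a group of 6 heavy atoms (3 carbon, 1 nitrogen, 2 oxygen; no ring) in place of a group of 5 heavy atoms (2 carbon, 1 nitrogen, 2 oxygen; no ring), on an oxygen on a saturated carbon. The place is the same, word for word, as in the change from compound 1 to compound 2, so this is the same change on another core.

Among the compounds with values here, the step from compound 3 to compound 4 is expected to be a 1.3-fold lower number from compound 3 to compound 4 (0.12 log units; within the scatter), resting on the only earlier instance of the change, a 1.4-fold lower number from compound 1 to compound 2 (0.14 log units; within the scatter), which stayed within the scatter. As far as these compounds go, whether the second core answers the change in the same way is unknown, so the range is kept wide. Compound 4 in this assay is estimated at 45 nM, with an expected span from 22 nM to 90 nM.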

Compound 4, half-maximal inhibitory concentration: 60 nM
For compound 4 the middle estimate is 1.3-fold (0.12 log units) below the measured one; measured number inside the range.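

The larger side chain on the core of compound 3 gives no change at the digits printed from compound 3 to compound 4 (within the scatter) in this assay, so this core shows no measurable response to the change. Set beside the earlier step, the change reads the same on both cores, with no difference that can be told apart in this series: the same change on two cores in this assay, a 1.4-fold lower number (0.14 log units; within the scatter) from compound 1 to compound 2 and no change at the digits printed (within the scatter) from compound 3 to compound 4, 1.4-fold (0.14 log units) apart, within the scatter of two such steps

Within the data shown here, this shows only that the change carried over from one core to the other without a step beyond the scatter on either; it does not show that the two cores respond identically, since a small real effect could lie hidden inside either step, and two pairs say nothing about a third core.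

The compounds shown leave open whether a side chain further from these two, for example one holding a primary amide or a longer chain on an oxygen on a saturated carbon, would produce a step beyond the scatter in this assay. Also open, as far as these compounds go, is which part of the difference between the two cores would govern any such response, as that difference is not broken down here.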